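The source may report more compounds than this note shows. Statements on the series, on what has been measured and on what is new or still open speak of the compounds shown alone.

Measured so far in a functional assay on HeLa cells (Homo sapiens) for inhibition, read by MTT assay; on this read-out higher numbers stand for weaker inhibition and lower numbers for stronger inhibition:
compound 1 `COc1ccc(/C=N/NC(=S)N/N=C2\C(=O)Nc3ccc(C)cc32)cc1O` gives 2730 nM;
compound 2 `Cc1ccc2c(c1)/C(=N/NC(=S)N/N=C/c1ccccn1)C(=O)N2` gives 3150 nM;
compound 3 `Cc1ccc2c(c1)/C(=N/NC(=S)N/N=C/c1c(F)cccc1Cl)C(=O)N2` gives 1510 nM.

Compound 3 holds the lowest of the three numbers: a 1.8-fold lower number from compound 1 to compound 3 (0.26 log units; within the scatter) stays within the scatter, while a 2.1-fold lower number from compound 2 to compound 3 (0.32 log units; beyond the scatter) goes beyond it, so compound 3 is not set apart from compound 1.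

Compound 4 `O=C1Nc2ccc(Br)cc2/C1=N/NC(=S)N/N=C/c1c(F)cccc1Cl` differs from compound 3 only at the core: bromo in place of methyl on an aromatic carbon. Going by the values given here, all three measured steps vary the group on the carbon with a double bond to nitrogen, and none touches this position, so no measured step bears on the change. The comparison starts from compound 3 at 1510 nM and the step of a 1.0-fold lower number from compound 3 to compound 4 (0.00 log units; within the scatter) is expected to stay within the scatter. For compound 4 the estimate in this assay is 1500 nM, ranging from 700 nM to 3200 nM.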

Compound 4, half-maximal inhibitory concentration: 1610 nM
The estimate for compound 4 lay 1.1-fold (0.03 log units) below the measured number, and the stated range covers the measured number.
By their numbers in this assay, from the lowest: compounds 3, 4, 1 and 2 (each within the scatter of the next, the first and the last beyond it).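

Going by these compounds alone, the first change at the core, bromo in place of methyl on an aromatic carbon, gives a 1.1-fold higher number from compound 3 to compound 4 (0.03 log units; within the scatter) in this assay. Within the data shown here, with the 2-chloro-6-fluorophenyl group held fixed, the two groups at this position are therefore not told apart, which the earlier steps, all made at the other end of the molecule, could not show. No evidence on hand accounts for this result.

Open, from the compounds shown here alone, is whether an amine, a carboxylic acid or a longer chain at this carbon would shift the number, and whether bromo and methyl also match with pyridin-2-yl or 3-hydroxy-4-methoxyphenyl in place of 2-chloro-6-fluorophenyl.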